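The compounds below may be only part of what the source reports. "The series", "measured", "known", "first", "only" and "open" are said of these compounds alone.

Measured compounds:

Compound 1 `O=C1Nc2ccc(Br)cc2C1=Cc1cccnc1` gives 31400 nM in an ADME assay on A549 cells (Homo sapiens) for cytotoxicity, read by MTT assay, with a stated time of 72 h; a higher number here means a weaker inhibitor, a lower number a stronger inhibitor.
Compound 2 `O=C1Nc2ccc(Br)cc2C1=Cc1ccncc1` gives 22300 nM in this assay.
Compound 3 `O=C1Nc2ccc([N+](=O)[O-])cc2C1=Cc1cccnc1` gives 429000 nM in this assay.

Compound 4 `O=C1Nc2ccc([N+](=O)[O-])cc2C1=Cc1ccncc1` has not yet been measured in this assay.

The change from compound 3 to compound 4 is pyridin-4-yl in place of pyridin-3-yl on a double-bonded chain carbon bound to a double-bonded ring carbon. The same change is made between the two measured compounds 1 and 2, where it is pyridin-4-yl in place of pyridin-3-yl on a double-bonded chain carbon bound to a double-bonded ring carbon, and it occurs twice among the compounds shown. In this assay the measured step was a 1.4-fold lower number from compound 1 to compound 2 (0.15 log units; within the scatter), a shift that does not stand apart from repeated measurement. The place of the change is the same in both pairs, so the change is the same, not merely the same kind. The two cores differ in that compound 3 carries nitro in place of bromo on an aromatic carbon, and this core difference alone produced the step of a 14-fold higher number from compound 1 to compound 3 (1.14 log units; beyond the scatter). No cause for that step is given by the data.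

For the measured compounds named here, the expectation for compound 4 rests on the single measured instance of the change, because a 1.4-fold lower number from compound 1 to compound 2 (0.15 log units; within the scatter) was within the scatter, and on the starting value of compound 3, 429000 nM. The step from compound 3 to compound 4 is therefore expected to be small, a 1.4-fold lower number from compound 3 to compound 4 (0.14 log units; within the scatter), with the wide range reflecting that the change has been seen only once and on a different core.

Compound 4 is expected to give about 310000 nM in this assay, estimated between 120000 nM and 800000 nM.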

Compound 4, half-maximal inhibitory concentration: "not toxic" (no number reported)
Nothing numeric was reported for compound 4; the estimate stays without a comparison.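

In this assay, for the compounds shown here, compound 4 is recorded only as "not toxic", without a number, so no step from compound 3 to compound 4 can be read. No supporting data bear on this result. The compounds shown leave open whether pyridin-4-yl in place of pyridin-3-yl, known numerically only as a 1.4-fold lower number from compound 1 to compound 2 (0.15 log units; within the scatter), has a comparable effect on the nitro-bearing core of compound 3.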